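This account rests on a few compounds, and the source may have more. Where it says the series, first, only, none or still open, it means among the compounds named here.

Measured so far in a physicochemical assay for acid dissociation:
compound 1 `CC(C)(C)c1ccc(Oc2ccc3c(NCCCNCc4ccco4)ccnc3c2)cc1`, 9.28
compound 2 `COc1cccc(CNCCCNc2ccnc3cc(-c4ccc(C(C)(C)C)cc4)ccc23)c1O`, 9.47
compound 3 `COc1ccc(F)cc1CNCCCNc1ccnc2cc(Cc3ccc(F)cc3Cl)ccc12`, 9.47

Compound 1 holds the lowest of the three numbers, yet the nearest, compound 2, and the furthest, compound 3, each sit only a difference within the usual scatter away, so the three cannot be told apart in this assay. Compound 4 `COc1cccc(Oc2ccc3c(NCCCNCc4ccco4)ccnc3c2)c1` is not yet measured; it differs from compound 1 by 3-methoxyphenyl in place of 4-(tert-butyl)phenyl on an oxygen on an aromatic ring. Going by the values given here, no step between measured compounds is known. Compounds 2 and 3 carry aryl groups unlike that of compound 1 and still return numbers within the scatter of its value, so the step of a number 0.02 log units higher from compound 1 to compound 4 (within the scatter) is expected to be none beyond the scatter. Compound 4 is estimated at 9.3, with a range from 9 to 9.6.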

Compound 4, acid dissociation constant: 9.28
The estimate for compound 4 lay 0.02 log units above the measured number; measured number inside the range.
By their numbers in this assay, from the lowest: compounds 1, 4, 2 and 3 (each within the scatter of the next).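

In this assay, going by these compounds alone, 3-methoxyphenyl in place of 4-(tert-butyl)phenyl on an oxygen on an aromatic ring gives no change at the digits printed from compound 1 to compound 4 (within the scatter), the only one-place comparison so far. Compounds 2 and 3 differ from compound 1 in more than one place, so they could not isolate this position. This single change, with fewer heavy atoms and a hydrogen-bond acceptor in the entering group, leaves the read-out within the scatter, and no supporting data explain the result. As far as these compounds go, whether an amine or a carboxylic acid at this position would move the number beyond the scatter remains open.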